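The source may hold more compounds than are shown below. What is called first, only, known or untested is meant among the compounds shown, and "the series" means these compounds.

Measured so far:
compound 1 `Cc1cccc(C)c1-c1cccc(COc2ccc3c(c2)CC3CC(=O)O)c1` — 1200 nM
compound 2 `O=C(O)CC1COc2cc(OCc3cccc(-c4csc5ccccc45)c3)ccc21` — 290 nM
compound 3 `COc1ccc(COc2ccc3c(c2)OCC3CC(=O)O)cc1-c1c(C)cccc1C` — 130 nM

In an assay on CHO cells for displacement of a labelled ligand from Free fatty acid receptor 1 (Homo sapiens), read by scintillation counting, with a stated time of 90 min, in the presence of a further agent that is not named here (a lower number here means a stronger inhibitor, a higher number a weaker inhibitor), compound 2 gives the second highest of these three numbers, a weaker inhibitor than compound 3 and a stronger one than compound 1, both gaps beyond the usual scatter. Compound 4 `Cc1ccc(-c2cccc(COc3ccc4c(c3)OCC4CC(=O)O)c2)c(C)c1` is drawn from compound 2 by a single swap: 2,4-dimethylphenyl in place of 1-benzothiophen-3-yl on an aromatic carbon. Among the measured compounds shown here, no pair of measured compounds tells what this swap alone does. Compound 3, on the shared core of compound 2, shows that a different side group can sit there and still bind, while compound 1 shows a weaker result on another core. The step is expected to be small, in either direction, probably within the scatter: a 1.0-fold higher number from compound 2 to compound 4 (0.01 log units; within the scatter). Compound 4 is therefore estimated at 300 nM, with a range of 80 nM to 1200 nM.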

Compound 4, inhibition constant in the Free fatty acid receptor 1 assay: 57 nM
The estimate for compound 4 lay 5.3-fold (0.72 log units) above the measured number, outside the stated range (below it).
By their numbers in the Free fatty acid receptor 1 assay, from the lowest: compound 4; then compound 3; then compound 2; then compound 1.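

In the Free fatty acid receptor 1 assay compound 2 gives 290 nM and compound 4 gives 57 nM with 2,4-dimethylphenyl in place of 1-benzothiophen-3-yl, which is a 5.1-fold lower number from compound 2 to compound 4 (0.71 log units; beyond the scatter), so at this position a single six-membered aromatic ring of carbon only can replace the larger group, and the result depends on which group sits there. In a physicochemical assay for lipophilicity, measured as octanol-water partition, at pH 7.4 (a lower number here means a more polar compound, a higher number a more lipophilic compound), compound 2 gives 3.99 and compound 4 gives 4.15 with the same swap, which is a number 0.16 log units higher from compound 2 to compound 4 (within the scatter), so the better binding number does not come with a real rise in this number. Nothing measured here explains the step. Which methyl group matters most remains open, as does how a plain phenyl or a pyridine ring would fare at this position.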